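The compounds below may be only part of what the source reports. "The series", "measured", "known", "first", "only" and "open" are said of these compounds alone.

Compound 2 `Oc1ccc(-c2cc(-c3ccoc3)cc(-c3cccc(O)c3)n2)cc1` carries a furan-3-yl group on its shared core, together with a 3-hydroxyphenyl group and a 4-hydroxyphenyl group. In an assay on isolated protein for inhibition of DNA topoisomerase 1 (Homo sapiens), with a stated time of 30 min, tested at 100 uM (on this read-out higher numbers stand for a stronger effect at the one concentration tested and lower numbers for a weaker effect), compound 2 gives 37.4%. Among the three measured compounds it stands second highest: compound 1 `Oc1cccc(-c2cc(-c3ccoc3)cc(-c3ccccc3O)n2)c1` gives 29.5%, and the step of a number 7.9 percentage points higher from compound 1 to compound 2 (within the scatter) lies within the scatter, whereas compound 3 `Oc1ccc(-c2cc(-c3ccoc3)cc(-c3ccc(O)cc3)n2)cc1` gives 74.9%, and the step of a number 37.5 percentage points higher from compound 2 to compound 3 (beyond the scatter) goes beyond it. Compound 4 `Oc1ccc(-c2cc(-c3ccccn3)cc(-c3cccc(O)c3)n2)cc1` differs from compound 2 in one place: pyridin-2-yl in place of furan-3-yl on an aromatic carbon. Neither measured step bears on this change: both exchange one hydroxyphenyl group for another and leave the furan-3-yl group untouched, so nothing measured shows how this position responds. Without any comparable step, the step of a number 2.6 percentage points higher from compound 2 to compound 4 (within the scatter) is expected to stay within the scatter, in no clear direction. The estimate for compound 4 is therefore 40%, with a wide range from 15% to 70% that reflects this lack of guidance.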

Compound 4, a percentage reported as inhibition, at one concentration (the size of the read-out at that concentration, not a potency): 2.4%
For compound 4 the middle estimate is 37.6 percentage points above the measured one, and the stated range ends above it.
By their numbers in this assay, from the lowest: compound 4; then compounds 1 and 2 (each within the scatter of the next); then compound 3.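

At the position opposite the ring nitrogen of the shared core, pyridin-2-yl in place of furan-3-yl gives a number 35 percentage points lower from compound 2 to compound 4 (beyond the scatter) in this assay, with the 3-hydroxyphenyl and 4-hydroxyphenyl groups left unchanged, so this place responds strongly, which the exchanges among hydroxyphenyl groups could not show. The two groups have the same counts of hydrogen-bond donors and acceptors and no net charge, but they differ in ring size and in the hetero atom. Nothing measured here explains the drop.

The compounds shown leave open whether a phenyl, pyridin-4-yl or furan-2-yl group at this position would behave like furan-3-yl or like pyridin-2-yl. They also leave open whether the same exchange would have a similar effect alongside the two 4-hydroxyphenyl groups of compound 3.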